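The source may hold more compounds than are shown below. What is called first, only, known or untested is meant among the compounds shown, and "the series" means these compounds.

Compound 1 `O=C(NCc1ccc(S(=O)(=O)c2cccc(C(F)(F)F)c2)cc1)c1cc2ccncc2o1`: 3 nM
Compound 2 `O=C(NCc1ccc(S(=O)(=O)N2CCCCC2)cc1)c1cc2ccncc2o1`: 29 nM

In a functional assay on A2780 cells (Homo sapiens) for inhibition, read by sulforhodamine B assay, with a stated time of 72 h (on this read-out higher numbers stand for weaker inhibition and lower numbers for stronger inhibition), compound 1 has the lower of the two numbers, 3 nM. Within the data shown here, the only measured step is a 9.7-fold higher number from compound 1 to compound 2 (0.99 log units; beyond the scatter). That step changes the group on the sulfonyl sulfur, not the group on the carbonyl carbon.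

Compound 3 `O=C(NCc1ccc(S(=O)(=O)c2cccc(C(F)(F)F)c2)cc1)c1cc2ccncc2s1` keeps the 3-(trifluoromethyl)phenyl group on the sulfonyl sulfur and changes the other end: a group of 9 heavy atoms (7 carbon, 1 nitrogen, 1 sulfur; one five-membered aromatic ring with 1 hetero atom, one six-membered aromatic ring with 1 hetero atom) in place of a group of 9 heavy atoms (7 carbon, 1 nitrogen, 1 oxygen; one five-membered aromatic ring with 1 hetero atom, one six-membered aromatic ring with 1 hetero atom), on a carbonyl carbon. Among the measured compounds shown here, no measured step touches this place, so the size of the step from compound 1 to compound 2 gives no direct guide. The expectation therefore starts from compound 1 at 3 nM, and no change beyond the scatter is expected in this assay, in either direction. The estimated change is a 1.3-fold higher number from compound 1 to compound 3 (0.12 log units; within the scatter). Compound 3 is expected at 4 nM, with an estimated range of 1.5 nM to 12 nM.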

Compound 3, half-maximal inhibitory concentration: 1 nM
Beside the measured number, compound 3's estimate is 4.0-fold (0.60 log units) above it; the whole stated range lies above it.
By their numbers in this assay, from the lowest: compound 3; then compound 1; then compound 2.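

Among these compounds, at the carbonyl carbon, the group containing sulfur in place of oxygen gives a 3.0-fold lower number from compound 1 to compound 3 (0.48 log units; beyond the scatter) in this assay, so this place, which no earlier step had touched, also responds to change. The two groups have the same counts of heavy atoms, rings, hydrogen-bond donors and acceptors, and no net charge, so exchanging oxygen for sulfur is enough to move the number beyond the scatter while keeping 3-(trifluoromethyl)phenyl on the sulfonyl sulfur. No evidence is available on what underlies this difference.

The compounds shown leave open whether the same exchange would give a similar step with piperidin-1-yl on the sulfonyl sulfur. They also leave open how the number would respond to a simple phenyl ring or a short alkyl chain on the carbonyl carbon.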